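Phenyl for Methyl at the Core Carbon

The source may hold more compounds than are shown below. What is called first, only, known or untested is meant among the compounds shown, and "the series" means these compounds.

Three compounds that share one core have been examined in an assay on BTI-TN-5B1-4 cells for inhibition of Amine oxidase [flavin-containing] A (Homo sapiens), read by fluorescence and Amplex Red, using microsomes, with a stated time of 30 min; on this read-out lower numbers stand for stronger inhibition and higher numbers for weaker inhibition. Compound 1 `C#CCOc1cccc(-c2cc(-c3cccc(OCC#C)c3)nc(N)n2)c1` is reported there as "not active" (no number reported), with no number attached to it. Compound 2 `C#CCOc1ccc(-c2cc(-c3ccccc3OCC#C)nc(N)n2)cc1` gives 28600 nM in this assay, and compound 3 `C#CCOc1ccc(-c2cc(-c3ccc(OCC#C)cc3)nc(C)n2)cc1` gives 34200 nM. Of the two numbers shown, compound 3 carries the higher one, but its gap to compound 2 lies within the scatter of this assay, so the two compounds stand together and no order between them can be read. Compound 1 adds no number to the comparison.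

Compound 4 `C#CCOc1ccc(-c2cc(-c3ccc(OCC#C)cc3)nc(-c3ccccc3)n2)cc1` is the untested partner of compound 3. The change is phenyl in place of methyl on an aromatic carbon. For the measured compounds named here, no pair of measured compounds shows what such an exchange does in this assay, so the direction of the step is open; a considerably larger group enters at the same place, and weak starting points of this kind can move either way. The step of a 1.4-fold lower number from compound 3 to compound 4 (0.14 log units; within the scatter) is expected to be no larger than the scatter allows, in the absence of any guiding pair. Compound 4 is therefore expected to give about 25000 nM in this assay, within a range from 6000 nM to 100000 nM, with a real chance that only a limit is reported.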

Compound 4, half-maximal inhibitory concentration: 25600 nM
The estimate for compound 4 lay 1.0-fold (0.01 log units) below the measured number, within the range that was stated.
By their numbers in this assay, from the lowest: compounds 4, 2 and 3 (each within the scatter of the next).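

The exchange of methyl for phenyl on the aromatic carbon between two ring nitrogen atoms now has a measured pair in this assay and the step of a 1.3-fold lower number from compound 3 to compound 4 (0.13 log units; within the scatter) lies within the scatter. At this carbon, then, a group of 6 heavy atoms with a six-membered aromatic ring of carbon only can stand in place of a single methyl carbon while the numbers of the two compounds remain together, and compound 4 still gives a number rather than a report of "not active". No measurement at hand bears on why this exchange leaves the numbers together.

For the compounds shown here, compounds 1 and 2 carry an amine at this carbon, but each also differs from compound 3 elsewhere, so no single step for that group can be read. Going by these compounds, whether a carboxylic acid, a hydroxyl group or a longer chain such as butyl at the same carbon would also leave the number within the scatter of compound 3 remains open.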